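The compounds below may be only part of what the source reports. "The series", "measured", "known", "first", "only" and "open" are said of these compounds alone.

Of the compounds shown here, three built on one shared core have been tested in a functional assay on MCF7 cells (Homo sapiens) for antiproliferative activity, read by MTT assay, with a stated time of 72 h; on this read-out lower numbers stand for stronger inhibition and higher numbers for weaker inhibition. Compound 1 `COc1cc(-c2ncnn2-c2ccc(N)cc2)cc(OC)c1OC` carries an amino group on an aromatic carbon. In this assay compound 1 gives only a limit of the assay, > 10000 nM. Compound 3 `COc1cc(-c2ncnn2-c2ccccc2)cc(OC)c1OC` carries hydrogen in place of that amino group. In this assay compound 3 likewise reaches only a limit, > 10000 nM. The step that the two limits leave unreadable from compound 1 to compound 3 is therefore unreadable, since both ends are limits rather than numbers.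

Compound 2 `COc1cc(-n2ncnc2-c2ccc(OC(F)(F)F)cc2)cc(OC)c1OC` carries a trifluoromethoxy group on an aromatic carbon. In this assay compound 2 also gives only a limit, > 10000 nM. Among the measured compounds shown here, compound 2 thus stands exactly where the other two compounds stand, because every value so far sits at the limit of > 10000 nM in this assay, at which 3 of the 3 values shown sit.

Compound 4 `COc1cc(-n2ncnc2-c2ccc(F)cc2)cc(OC)c1OC` has not yet been measured. It differs from compound 2 in one place: fluoro in place of trifluoromethoxy on an aromatic carbon. For the measured compounds named here, no measured step bears on this change; the single step available, from compound 1 to compound 3, concerns a different group and cannot be read in size. With all three values at a limit, the step that the limit leaves unreadable from compound 2 to compound 4 is expected to stay within the scatter, with the assay most likely again reporting only a limit. Compound 4 is expected to give about 15000 nM, in a range from 5000 nM to 50000 nM.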

Compound 4, half-maximal inhibitory concentration: > 10000 nM
Compound 4 was reported as a limit (the forecaster's own chance of this, stated with the estimate: 80%); the middle value lies beyond the limit too.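

Compound 2 and compound 4 both give only a limit of the assay rather than a number, and the step between them cannot be read. All the compounds shown stand at one place: the limit of > 10000 nM in this assay, at which 4 of the 4 values shown sit.

The compounds shown leave open which change to the shared core or its groups, if any, would give a measurable value.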